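The source may hold more compounds than are shown below. What is called first, only, known or untested is meant among the compounds shown, and "the series" means these compounds.

Measured compounds:
compound 1, `Cc1cccc(Cc2nc3ccc(O[C@H]4CC[C@@H](C(=O)O)CC4)cc3n2C)c1`, > 200000 nM
compound 2, `Cc1ccc(Cc2nc3cc(O[C@H]4CC[C@@H](C(=O)O)CC4)ccc3n2C)cc1`, 150 nM

Of the compounds shown here, two sharing a core have been tested in an assay on isolated protein for inhibition of Long-chain-fatty-acid--CoA ligase 1 (Homo sapiens), read by mass spectrometry, with a stated time of 90 min, in the presence of a further agent that is not named here; on this read-out lower numbers stand for stronger inhibition and higher numbers for weaker inhibition. Compound 1 gives only a limit of the assay, > 200000 nM, with no number behind it. Among the compounds with values here, compound 2 gives 150 nM and is the only compound with a numerical value in this assay. The other value shown for this series is a limit (the limit of > 200000 nM in this assay, at which 1 of the 2 values shown sits), so compound 2 stands alone as the one measured point.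

Compound 3, `Cc1cccc(COc2nc3cc(O[C@H]4CC[C@@H](C(=O)O)CC4)ccc3n2C)c1`, has not yet been measured in this assay. It differs from compound 2 in one place: (3-methylbenzyl)oxy in place of 4-methylbenzyl on an aromatic carbon. No measured pair follows this change, so nothing shown tells how large its effect will be. Compound 3 is expected to be weaker than compound 2, with a step of a 33-fold higher number from compound 2 to compound 3 (1.52 log units; beyond the scatter) well beyond the scatter. The estimate for compound 3 in this assay is 5000 nM, within a range from 500 nM to 100000 nM.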

Compound 3, half-maximal inhibitory concentration: 17000 nM
Estimate against measurement, compound 3: 3.4-fold (0.53 log units) below, within the range that was stated.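

In this assay, within the data shown here, the aromatic carbon between two ring nitrogen atoms proves sensitive to the group it carries: (3-methylbenzyl)oxy in place of 4-methylbenzyl gives a 110-fold higher number from compound 2 to compound 3 (2.05 log units; beyond the scatter), the first step that can be read at this place. Compound 3 still gives a number and not a limit of the assay, so the change weakens inhibition greatly without taking it out of the measured range. The change is a double one, however: the entering group brings in an oxygen, counted as a hydrogen-bond acceptor, and its name carries the methyl at 3 and not at 4, so this single step cannot be divided between the two.

Nothing shown gives a measured property that would account for the size of this step. From the compounds shown here alone, it remains open whether (4-methylbenzyl)oxy at this carbon would fall closer to compound 2 at 150 nM or to compound 3, and how a benzylamine or a longer carbon chain at the same place would read.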